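Adenosine A2b binding: moving the furan one carbon out

The source may hold more compounds than are shown below. What is called first, only, known or untested is meant among the compounds shown, and "the series" means these compounds.

Measured compounds:
compound 1 `CCCn1c(=O)c2[nH]c(-c3ccccc3)nc2n(CCCOC)c1=O`: 324 nM
compound 2 `CCSCCn1c(=O)c2[nH]c(-c3ccco3)nc2n(CCCOC)c1=O`: 490 nM

In an assay on HEK293 cells for binding affinity to adenosine receptor A2b (Homo sapiens) (a higher number here means a weaker inhibitor, a lower number a stronger inhibitor), compound 1 gives 324 nM and compound 2 gives 490 nM. Compound 2 has the higher of the two numbers, yet its gap to compound 1 lies within the scatter, so no order between them can be claimed.

Compound 3 `CCSCCn1c(=O)c2[nH]c(Cc3ccco3)nc2n(CCCOC)c1=O` differs from compound 2 in one place: (furan-2-yl)methyl in place of furan-2-yl on an aromatic carbon. Going by the values given here, no measured pair shows the effect of such a change, so the expectation rests on the change alone. A moderate step toward a higher number, beyond the scatter, is expected, as a 3.1-fold higher number from compound 2 to compound 3 (0.49 log units; beyond the scatter). Compound 3 is therefore estimated at 1500 nM, with a range from 400 nM to 6000 nM.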

Compound 3, inhibition constant: 2000 nM
Compound 3: middle estimate off by 1.3-fold (0.12 log units), on the low side, within the range that was stated.
By their numbers in this assay, from the lowest: compounds 1 and 2 (each within the scatter of the next); then compound 3.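

In this assay, (furan-2-yl)methyl in place of furan-2-yl on this aromatic carbon gives a 4.1-fold higher number from compound 2 to compound 3 (0.61 log units; beyond the scatter). This shows that the position, between two ring nitrogen atoms, responds to how the furan is attached, even though the ring itself and the hydrogen-bond donor and acceptor counts stay the same. Nothing available accounts for this step.

As far as these compounds go, it remains open whether a longer chain, such as 2-(furan-2-yl)ethyl, would extend this trend. From the compounds shown here alone, it is also open whether benzyl in place of the phenyl of compound 1 would give a step of similar size.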